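Aryloxy quinoline series: chain-to-phenyl change at the ether

The source may hold more compounds than are shown below. What is called first, only, known or untested is meant among the compounds shown, and "the series" means these compounds.

Three compounds have a number in a functional assay on BGC-823 cells (Homo sapiens) for cytotoxicity, read by MTT assay, with a stated time of 48 h; on this read-out higher numbers stand for weaker inhibition and lower numbers for stronger inhibition. Compound 1 `CCCCCCCCOc1ccc2c(Cl)ccnc2c1` gives 4300 nM, the highest of the three numbers and so the weakest inhibition in this set. Compound 2 `C=CCOc1ccc2c(NCCN(C)C)ccnc2c1` gives 1360 nM, and compound 3 `CN(C)CCCNc1ccnc2cc(OCc3ccc(F)cc3)ccc12` gives 490 nM; both lie beyond the usual scatter from compound 1, compound 3 furthest. Compounds 2 and 3 carry a different group on the core, so their values say little about the ether chain alone.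

Compound 4 `Clc1ccnc2cc(OCCCc3ccccc3)ccc12` is compound 1 with one change: phenyl in place of pentyl on a saturated chain carbon, three bonds along the chain from an oxygen on an aromatic ring. For the measured compounds named here, no pair of measured compounds isolates this change, so the size of the step rests on judgement. Going by the values given here, compound 3, the only measured compound with an aromatic ring in the ether side chain, shows the lowest number at 490 nM, which gives weak support for a modest gain. The step from compound 1 to compound 4 is therefore expected to be a 1.7-fold lower number from compound 1 to compound 4 (0.24 log units; within the scatter), small and toward stronger inhibition, possibly within the scatter. Compound 4 is estimated at 2500 nM, with a range from 1000 nM to 6000 nM.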

Compound 4, half-maximal inhibitory concentration: 2370 nM
Estimate against measurement, compound 4: 1.1-fold (0.02 log units) above; the range from low to high includes it.
By their numbers in this assay, from the lowest: compound 3; then compounds 2, 4 and 1 (each within the scatter of the next, the first and the last beyond it).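

In this assay, phenyl in place of pentyl on a saturated chain carbon, three bonds along the chain from an oxygen on an aromatic ring, gives a 1.8-fold lower number from compound 1 to compound 4 (0.26 log units; within the scatter), so at this position the two groups cannot be told apart. For the compounds shown here, this is the first pair that isolates the end of the ether chain, and it shows that a six-membered aromatic ring of carbon is tolerated there as well as an open chain. No measurement on these compounds offers a cause for this result.

As far as these compounds go, whether a pyridine ring, a carboxylic acid or an amine at the end of the chain would move the number beyond the scatter remains open. Also open, from the compounds shown here alone, is whether the step from pentyl to phenyl keeps its size on the core of compound 3.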